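The source may hold more compounds than are shown below. What is called first, only, known or untested is meant among the compounds shown, and "the series" means these compounds.

Three compounds built on one shared core were tested in an ADME assay on L02 cells (Homo sapiens) for antiproliferative activity, read by MTT assay, with a stated time of 48 h; on this read-out lower numbers stand for stronger inhibition and higher numbers for weaker inhibition. Compound 1 `CCOc1ccccc1-n1nncc1CN1C(=O)C2(C(C#N)=C(N)Oc3c2c2nc4ccccc4nc2c2ccccc32)c2ccccc21` in this assay gives > 50000 nM, which is a limit of the assay rather than a number. Compound 2 `N#CC1=C(N)Oc2c(c3nc4ccccc4nc3c3ccccc23)C12C(=O)N(Cc1cnnn1-c1cc(Cl)ccc1Cl)c1ccccc12` in this assay gives > 50000 nM, again a limit. The step that the two limits leave unreadable from compound 1 to compound 2 therefore cannot be read in either direction. Compound 3 `N#CC1=C(N)Oc2c(N)cc3nc4ccccc4nc3c2C12C(=O)N(Cc1cnnn1-c1ccc(Cl)cc1)c1ccccc12` in this assay gives > 50000 nM, also a limit. Compound 3 thus stands where the other two stand, at the limit of > 50000 nM in this assay, at which 3 of the 3 values shown sit, and no ordering among the three can be drawn from these numbers.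

Compound 4 `Cc1ccc(Cl)cc1-n1nncc1CN1C(=O)C2(C(C#N)=C(N)Oc3c(N)cc4nc5ccccc5nc4c32)c2ccccc21` has not yet been measured. It differs from compound 3 in a single place: 5-chloro-2-methylphenyl in place of 4-chlorophenyl on an aromatic nitrogen. For the measured compounds named here, no measured step bears on this particular change, as the only available step, the one from compound 1 to compound 2, was left unreadable by the two limits. With every measured value sitting at the limit, the step that the limit leaves unreadable from compound 3 to compound 4 is expected to be no larger than the scatter, and compound 4 is expected to sit at the limit as well. Compound 4 is estimated at 60000 nM, with a range from 25000 nM to 150000 nM, and is most likely to be reported only as a limit.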

Compound 4, half-maximal inhibitory concentration: > 50000 nM
Compound 4 was reported as a limit; the forecaster's own chance of this, stated with the estimate: 85%; the middle value is on the limit's open side.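

For the compounds shown here, compound 3 and compound 4 are each reported only as a limit, so the change from 4-chlorophenyl to 5-chloro-2-methylphenyl gives no step that can be read: the limit of > 50000 nM in this assay, at which 4 of the 4 values shown sit. The compounds shown leave open the actual value of each compound in this assay and therefore any ordering among all four.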